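A few compounds are considered here, and "the series" means these few. Any claim that something is new, unique, unknown or untested is made for them only; others in the source may bear on it.

Measured so far:
compound 1, `Cc1ccc2[nH]c(-c3cn(-c4ccccc4)nc3-c3ccccc3)nc2c1`, > 50000 nM;
compound 2, `FC(F)(F)c1ccc2[nH]c(-c3cn(-c4ccccc4)nc3-c3ccccc3)nc2c1`, 37200 nM;
compound 3, `FC(F)(F)c1ccc2[nH]c(-c3cn(-c4ccccc4)nc3-c3ccc(Cl)cc3)nc2c1`, 41800 nM.

The three compounds were tested in an ADME assay on HaCaT cells (Homo sapiens) for cytotoxicity, read by MTT assay, with a stated time of 48 h; a higher number here means a weaker inhibitor, a lower number a stronger inhibitor. In this assay compound 2 gives 37200 nM and compound 3 gives 41800 nM. For compound 1 the assay reports only a limit, > 50000 nM, which is the limit of > 50000 nM in this assay, at which 1 of the 3 values shown sits.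

Compound 2 and compound 3 share one core and differ by chloro in place of hydrogen on an aromatic carbon; this step gives a 1.1-fold higher number from compound 2 to compound 3 (0.05 log units; within the scatter). Compound 2 and compound 1 differ by methyl in place of trifluoromethyl on an aromatic carbon, and that change produced an at least 1.3-fold higher number from compound 2 to compound 1 (0.12 log units; that floor lies within the scatter), carrying the value up to the limit of the assay.

The compound not yet measured is compound 4, `Cc1ccc2[nH]c(-c3cn(-c4ccccc4)nc3-c3ccc(Cl)cc3)nc2c1`. It differs from compound 3 by methyl in place of trifluoromethyl on an aromatic carbon. Among the compounds with values here, this is the same change as the one between compound 2 and compound 1, made on the same place of the core, so the two steps are of the same kind. On that basis compound 4 is expected to follow the same course: the step is estimated as a 1.3-fold higher number from compound 3 to compound 4 (0.12 log units; within the scatter) in this assay, resting on compound 3 at 41800 nM and on the earlier step of an at least 1.3-fold higher number from compound 2 to compound 1 (0.12 log units; that floor lies within the scatter). The value of compound 4 is therefore estimated at 55000 nM, within a range from 35000 nM to 100000 nM, most likely reported only as a limit.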

Compound 4, half-maximal inhibitory concentration: > 50000 nM
Compound 4: a limit, no number; the forecaster's own chance of this, stated with the estimate: 60%; the middle value is on the limit's open side.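

In this assay compound 4 gives > 50000 nM, which is a limit of the assay and not a number. Methyl in place of trifluoromethyl on this core is therefore recorded only as an at least 1.1-fold higher number from compound 3 to compound 4 (0.07 log units; that floor lies within the scatter), while the step that adds chloro in place of hydrogen on the methyl compounds cannot be read, since both of its ends are limits. Carried from one core to the other, the change ends at the limit both times, which shows that the two results are compatible but not that the change has the same size on both cores: the same change on two cores in this assay, an at least 1.3-fold higher number (0.12 log units; that floor lies within the scatter) from compound 2 to compound 1 and an at least 1.1-fold higher number (0.07 log units; that floor lies within the scatter) from compound 3 to compound 4; the limit leaves it open whether they differ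

The compounds shown leave open how far past the limit compound 1 and compound 4 lie, and so whether the methyl compounds differ from each other at all: the limit of > 50000 nM in this assay, at which 2 of the 4 values shown sit. They also leave open how an amine or a carboxylic acid would read in this assay if placed on the same aromatic carbon in place of methyl or trifluoromethyl, on either core.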